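The compounds below may be only part of what the source reports. "The series", "measured", "known", "first", "only" and "open" are said of these compounds alone.

Compound 1 `CN(C)CCn1c(N)c(-c2nc3ccccc3[nH]2)c2nc(C#N)c(C#N)nc21` carries a dimethylamino group at the end of a two-carbon chain, and in a functional assay on HeLa cells (Homo sapiens) for antiproliferative activity, read by MTT assay, with a stated time of 48 h (on this read-out higher numbers stand for weaker inhibition and lower numbers for stronger inhibition), compound 1 gives 8880 nM. Compound 2 `CCN(CC)CCn1c(N)c(-c2nc3ccccc3[nH]2)c2nc(C#N)c(C#N)nc21` differs from it by diethylamino in place of dimethylamino on a saturated chain carbon, two bonds along the chain from an aromatic nitrogen, and in this assay compound 2 gives 11600 nM, so that a 1.3-fold higher number from compound 1 to compound 2 (0.12 log units; within the scatter). Compound 3 `CN(C)CCCn1c(N)c(-c2nc3ccccc3n2C)c2nc(C#N)c(C#N)nc21` has a different core; how its core differs from that of compound 1 is not broken down here. In this assay compound 3 gives 4320 nM, the lowest of the three numbers. Compound 4 `CCN(CC)CCCn1c(N)c(-c2nc3ccccc3n2C)c2nc(C#N)c(C#N)nc21` is compound 3 with diethylamino in place of dimethylamino on a saturated chain carbon, three bonds along the chain from an aromatic nitrogen. This is the same kind of change as that from compound 1 to compound 2, with the saturated chain carbon three rather than two bonds along the chain from the aromatic nitrogen. Because a 1.3-fold higher number from compound 1 to compound 2 (0.12 log units; within the scatter) is within the scatter, the step from compound 3 to compound 4 is expected to be similar, a 1.3-fold higher number from compound 3 to compound 4 (0.11 log units; within the scatter). Compound 4 is therefore estimated at 5600 nM, between 2800 nM and 11500 nM.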

Compound 4, half-maximal inhibitory concentration: 12400 nM
Estimate against measurement, compound 4: 2.2-fold (0.35 log units) below; the whole stated range lies below it.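

In this assay, diethylamino in place of dimethylamino gives a 2.9-fold higher number from compound 3 to compound 4 (0.46 log units; beyond the scatter), and this step is set beside the earlier one on the other core: the same change on two cores in this assay, a 1.3-fold higher number (0.12 log units; within the scatter) from compound 1 to compound 2 and a 2.9-fold higher number (0.46 log units; beyond the scatter) from compound 3 to compound 4, 2.2-fold (0.34 log units) apart, within the scatter of two such steps. The two steps therefore cannot be told apart, which is consistent with the change carrying from one core to the other. The pairs do not show that the step keeps a fixed size or that it depends on the core, and the 2-(diethylamino)ethyl and 3-(diethylamino)propyl pairs also differ in their chains, so any difference could not be assigned to one feature.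

The compounds shown leave open how a dipropylamino group would read in this assay. They also leave open whether a longer chain would give a similar step.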